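Methyl and trifluoromethyl on the pyrazole: lipophilicity notes

The source may hold more compounds than are shown below. What is called first, only, known or untested is meant among the compounds shown, and "the series" means these compounds.

Measured so far in a physicochemical assay for lipophilicity, using the shake flask method, at pH 7.4; on this read-out lower numbers stand for lower lipophilicity and higher numbers for higher lipophilicity:
compound 1, `CCCC(Oc1ccc(-n2cccn2)cc1)c1ccc(C(=O)NCCC(=O)O)cc1` — 1.7
compound 2, `CCCC(Oc1ccc(-n2cc(C)cn2)cc1)c1ccc(C(=O)NCCC(=O)O)cc1` — 2.1
compound 3, `CCCC(Oc1ccc(-n2cc(C(F)(F)F)cn2)cc1)c1ccc(C(=O)NCCC(=O)O)cc1` — 2.4

All three share one core and differ only on the pyrazole. The change methyl in place of hydrogen on an aromatic carbon gives a number 0.40 log units higher from compound 1 to compound 2 (beyond the scatter). The change trifluoromethyl in place of hydrogen on an aromatic carbon gives a number 0.70 log units higher from compound 1 to compound 3 (beyond the scatter). Between compound 2 and compound 3 the gap is a number 0.30 log units higher from compound 2 to compound 3 (within the scatter). Compound 3 stands highest of the three, though its separation from compound 2 is within the scatter.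

Compound 4, `CCCC(Oc1ccc(-n2cc(C(F)(F)F)cn2)c(C)c1)c1ccc(C(=O)NCCC(=O)O)cc1`, awaits measurement in this assay. Relative to compound 3 the difference is methyl in place of hydrogen on an aromatic carbon. This is the same kind of change as that from compound 1 to compound 2, and it occurs twice among the compounds here, but it is not the same change: in compound 2 the methyl sits on an aromatic carbon of a five-membered aromatic ring with 2 nitrogen, two ring bonds from the ring nitrogen and two ring bonds from the ring atom that bears a large group, whereas in compound 4 it sits on an aromatic carbon of a six-membered aromatic ring of carbon only, ortho to a 4-(trifluoromethyl)-1H-pyrazol-1-yl group and meta to a large group. The two cores differ by trifluoromethyl in place of hydrogen on an aromatic carbon.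

Among the compounds with values here, for compound 4 a step of about a number 0.50 log units higher from compound 3 to compound 4 (beyond the scatter) is expected, resting on the only comparable step here, a number 0.40 log units higher from compound 1 to compound 2 (beyond the scatter), with allowance for the different place. Compound 4 is therefore estimated at 2.9, most likely between 2.6 and 3.2.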

Compound 4, distribution coefficient: 2.6
Beside the measured number, compound 4's estimate is 0.30 log units above it; the measured number falls inside the stated range.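

In this assay, methyl in place of hydrogen on an aromatic carbon of a six-membered aromatic ring of carbon only gives a number 0.20 log units higher from compound 3 to compound 4 (within the scatter), while the same kind of change on the five-membered aromatic ring with 2 nitrogen gave a number 0.40 log units higher from compound 1 to compound 2 (beyond the scatter), so a step beyond the scatter on one core did not reappear as a step beyond the scatter on the other. With one step of each kind, the place of the methyl and the core change together, so this pair cannot separate the two and gives no general rule for carrying the change across the series; a step within the scatter also does not show that this methyl has no effect on the read-out. Nothing measured here accounts for the difference between the two steps.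

Still open, as far as these compounds go, is what methyl at this same place gives on the core of compound 1, which would test the change without the trifluoromethyl on the pyrazole. Also open, from the compounds shown here alone, is how other groups in place of this hydrogen, such as ethyl, a nitrile or an amine, would read in this assay.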